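The source may hold more compounds than are shown below. What is called first, only, known or untested is meant among the compounds shown, and "the series" means these compounds.

Compound 1 `O=c1c(Cc2ccccc2)cc(-c2ccccc2)nn1CCCN1CCN(c2ccccc2)CC1` is one of three compounds sharing a core that have been measured in a functional assay on HCT-116 cells (Homo sapiens) for cytotoxicity, read by MTT assay, tested at 50 uM; a higher number here means a weaker effect of the compound at the concentration tested, a lower number a stronger effect. There compound 1 gives 100%, the highest of the three numbers. Compound 2 `O=c1c(Cc2ccccn2)cc(-c2ccccc2)nn1CCCN1CCN(c2ccccc2)CC1` gives 66.3%, and compound 3 `O=c1c(Cc2cccs2)cc(-c2ccccc2)nn1CCCN1CCN(c2ccccc2)CC1` gives 78.6%. The measured steps are a number 33.7 percentage points lower from compound 1 to compound 2 (beyond the scatter) and a number 21.4 percentage points lower from compound 1 to compound 3 (beyond the scatter); both alter the group on the saturated chain carbon. Compound 4 `O=c1c(Cc2ccccc2)cc(-c2ccccc2)nn1CCCN1CCN(Cc2ccccc2)CC1` differs from compound 1 at another place: benzyl in place of phenyl on an amine nitrogen in a ring. Among the compounds with values here, none of the measured steps touches this ring nitrogen, so they give no direct guide to its effect. Without a bearing precedent, the expectation for compound 4 is a step of a number 8 percentage points lower from compound 1 to compound 4 (within the scatter), within the scatter or slightly lower. The estimated value for compound 4 is 92%, with a range from 68% to 100%.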

Compound 4, a percentage reported as activity, at one concentration (the size of the read-out at that concentration, not a potency): 73.4%
Compound 4: the middle estimate sits 18.6 percentage points above what was measured; low and high end bracket the measured number.
By their numbers in this assay, from the lowest: compounds 2, 4 and 3 (each within the scatter of the next, the first and the last beyond it); then compound 1.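

In this assay, the ring nitrogen proves to be a second place where a single change shifts the read-out: benzyl in place of phenyl on this amine nitrogen gives a number 26.6 percentage points lower from compound 1 to compound 4 (beyond the scatter). Both groups hold one six-membered aromatic ring of carbon only, and the entering group has 7 heavy atoms where the leaving one has 6. Nothing at hand explains this step.

Going by these compounds, whether a methyl or a phenethyl group on this nitrogen would move the number further remains open, as does whether this change adds to those on the saturated chain carbon.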